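The source may report more compounds than this note shows. Statements on the series, on what has been measured and on what is new or still open speak of the compounds shown alone.

- compound 1 `CC#CCn1c(N2CCC[C@@H](N)C2)nc2c1c(=O)n(Cc1ccc(Br)cc1C(=O)OCC)c(=O)n2C` gives 98.4%
- compound 2 `CC#CCn1c(N2CCC[C@@H](N)C2)nc2c1c(=O)n(Cc1ccc(Br)cc1C(=O)O)c(=O)n2C` gives 99.2%

In a physicochemical assay for metabolic stability, read by LC-MS, in phosphate buffer, with a stated time of 120 min, at pH 7.4, tested at 1 uM (on this read-out lower numbers stand for a less stable compound and higher numbers for a more stable compound), compound 1 gives 98.4% and has a single measured neighbour, reached by the step of a number 0.8 percentage points higher from compound 1 to compound 2 (within the scatter) with hydrogen in place of ethyl on an oxygen next to a carbonyl group. Compound 3 (`CC#CCn1c(N2CCC[C@@H](N)C2)nc2c1c(=O)n(Cc1ccc(Cl)cc1C(=O)OCC)c(=O)n2C`) differs from compound 1 by chloro in place of bromo on an aromatic carbon. Within the data shown here, no measured step changes that halogen, so the step of a number 0.8 percentage points higher from compound 1 to compound 2 (within the scatter) bears on it only loosely. No change beyond the scatter is therefore expected in this assay for this swap. The expected step is a number 0.4 percentage points lower from compound 1 to compound 3 (within the scatter) and stays within the scatter. For compound 3 the estimated value is 98% with an expected range from 93% to 100% on this read-out.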

Compound 3, percent of the compound remaining: 99.5%
The estimate for compound 3 lay 1.5 percentage points below the measured number, and the stated range covers the measured number.
By their numbers in this assay, from the lowest: compounds 1, 2 and 3 (each within the scatter of the next).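

In this assay, among these compounds, chloro in place of bromo on the aromatic carbon para to a large group gives a number 1.1 percentage points higher from compound 1 to compound 3 (within the scatter) and is the first direct reading of a change at this position. The change to 4-chloro-2-(ethoxycarbonyl)phenyl from 4-bromo-2-carboxyphenyl gives a number 0.3 percentage points higher from compound 2 to compound 3 (within the scatter) and likewise leaves the read-out unchanged within the scatter. Nothing available offers an explanation for these results. As far as these compounds go, whether fluoro or methoxy at this position would behave the same remains open, as does the effect of an amide in place of the ethoxycarbonyl group.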